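A chloro added to the benzyl group of compound 2

The compounds below may be only part of what the source reports. "The series", "measured", "known", "first", "only" and "open" are said of these compounds alone.

Measured compounds:
Compound 1: `NNC(=O)Cc1cc(=O)oc2cc(OCc3cccc(Cl)c3)ccc12`; in an assay (strain Wistar) for inhibition of Amine oxidase [flavin-containing] A (Rattus norvegicus) (a lower number here means a stronger inhibitor, a higher number a weaker inhibitor), compound 1 gives 2500 nM
Compound 2: `NC(=O)Cc1cc(=O)oc2cc(OCc3ccccc3)ccc12`; in this assay compound 2 gives 8000 nM

Of the two measured compounds, compound 2 shows the highest number in this assay; its nearest neighbour, compound 1, gives a lower number, and the gap between them lies beyond the usual scatter. Compound 1 and compound 2 differ in more than one place, so no single step can be read from them. Compound 3, `NC(=O)Cc1cc(=O)oc2cc(OCc3cccc(Cl)c3)ccc12`, differs from compound 2 in one place: chloro in place of hydrogen on an aromatic carbon. The same chloro group sits on the benzyl group of compound 1, and this is the only hint the data offer. A step from compound 2 to compound 3 of moderate size, toward a lower number, is therefore expected in this assay, roughly a 2.3-fold lower number from compound 2 to compound 3 (0.36 log units; beyond the scatter). For compound 3 the estimate in this assay is 3500 nM, with a range from 1200 nM to 10000 nM.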

Compound 3, half-maximal inhibitory concentration: 26000 nM
Estimate against measurement, compound 3: 7.4-fold (0.87 log units) below; measured number above the stated range.
By their numbers in this assay, from the lowest: compound 1; then compound 2; then compound 3.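

In this assay, chloro in place of hydrogen on the benzyl group does not move the number in the direction compound 1 had suggested: the change gives a 3.3-fold higher number from compound 2 to compound 3 (0.51 log units; beyond the scatter) and so counts against the chloro group at this place when the amide nitrogen carries only hydrogen. With the 3-chlorobenzyl group held constant, hydrogen in place of amino on the amide-type nitrogen gives a 10-fold higher number from compound 1 to compound 3 (1.02 log units; beyond the scatter) and is the larger of the two steps, which shows that the amino group separates compound 1 from its close neighbour. No measurement shown accounts for either step.

The compounds shown leave open whether the chloro step would run the same way with amino on the amide-type nitrogen. They also leave open whether bromo or methyl on the benzyl group would follow chloro, and whether a methylamino group on that nitrogen would match amino.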